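Extending the hydroxycarbamoyl chain once more

This account rests on a few compounds, and the source may have more. Where it says the series, first, only, none or still open, it means among the compounds named here.

Measured in a functional assay on MCF7 cells (Homo sapiens) for antiproliferative activity, read by MTT assay, with a stated time of 72 h (a higher number here means a weaker inhibitor, a lower number a stronger inhibitor), so far:
Compound 1 `O=C(CCCn1cc(-c2ncnc3[nH]ccc23)cn1)NO` gives > 100000 nM (a limit)
Compound 2 `O=C(CCCCCCCn1cc(-c2ncnc3[nH]ccc23)cn1)NO` gives 12400 nM (a number)

Among the compounds with values here, compound 2 holds the only true number in this short series, while the single other reading is a limit. Compound 1 reads > 100000 nM and that value is a limit of the assay.

Compound 3 `O=C(CCCCCCCCCCn1cc(-c2ncnc3[nH]ccc23)cn1)NO` is not yet measured. The change to it is 3-(hydroxycarbamoyl)propyl in place of hydroxycarbamoyl on a saturated chain carbon, seven bonds along the chain from an aromatic nitrogen and the place is a saturated chain carbon, seven bonds along the chain from an aromatic nitrogen. The hydroxycarbamoyl end therefore moves further out along the chain, and the shared core stays as it is.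

Within the data shown here, one measured step bears on this, a change of the same kind: an at least 8.0-fold lower number from compound 1 to compound 2 (0.90 log units; beyond the scatter) and it lies beyond the scatter. Among the measured compounds shown here, its full size stays open because of the limit of > 100000 nM in this assay, at which 1 of the 2 values shown sits, and it is the only such step available, so it shows no trend. On the strength of that step, a further fall in this assay is expected, though a smaller one and with real uncertainty, and the estimated step is a 2.5-fold lower number from compound 2 to compound 3 (0.39 log units; beyond the scatter) in that same direction. Compound 3 is estimated at 5000 nM (expected range 1200 nM to 25000 nM).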

Compound 3, half-maximal inhibitory concentration: 13300 nM
The estimate for compound 3 lay 2.7-fold (0.42 log units) below the measured number, and the stated range covers the measured number.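

In this assay the further lengthening gives a 1.1-fold higher number from compound 2 to compound 3 (0.03 log units; within the scatter). Placing 3-(hydroxycarbamoyl)propyl in place of hydroxycarbamoyl on this saturated chain carbon, seven bonds along the chain from an aromatic nitrogen, therefore leaves the reading where it was, and the fall seen on the earlier lengthening (an at least 8.0-fold lower number from compound 1 to compound 2 (0.90 log units; beyond the scatter)) does not carry on, so the two steps together show no steady trend with chain length. Going by these compounds, the true size of that earlier fall stays open because one end of it is a limit of the assay, so the two steps cannot be compared in size: the limit of > 100000 nM in this assay, at which 1 of the 3 values shown sits.

The compounds shown leave open whether the flat stretch continues with a longer chain than that of compound 3, and how the reading behaves with chains of intermediate length, which would show where along the chain the fall ends. They also leave open whether the chain end itself matters at these lengths, as a carboxylic acid or a primary amide in place of the hydroxycarbamoyl group on the chain of compound 2 would show.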